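The source may report more compounds than this note shows. Statements on the series, on what has been measured and on what is new or still open speak of the compounds shown alone.

Measured compounds and their values:

Compound 1, `CCc1c(CC2CCCCC2)nc(SCc2ccccc2)[nH]c1=O`, gives 532 nM.
Compound 2, `Cc1c(CC2CCCCC2)nc(SCc2ccccc2)[nH]c1=O`, gives 1250 nM.
Compound 3, `CCc1c(Cc2ccccc2)nc(SCC(=O)c2ccccc2)[nH]c1=O`, gives 80.2 nM.

All three were tested in an ADME assay on C1866 cells (Homo sapiens) for cytotoxicity, read by MTT assay, with a stated time of 72 h; on this read-out lower numbers stand for an effect already at smaller amounts and higher numbers for an effect only at larger amounts of compound. Compounds 1 and 2 share one core and differ in a single place: methyl in place of hydrogen on a saturated chain carbon bound to an aromatic carbon. That step, a 2.3-fold lower number from compound 2 to compound 1 (0.37 log units; beyond the scatter), is modest but beyond the usual scatter. Compound 3 carries a different core; the difference between the two cores is not broken down here. Among the three numbers, compound 3 stands lowest, and its value sits well apart from those of compound 1 and compound 2.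

Compound 4, `CC(C)c1c(Cc2ccccc2)nc(SCC(=O)c2ccccc2)[nH]c1=O`, has not been tested. It differs from compound 3 as follows: methyl in place of hydrogen on a saturated chain carbon bound to an aromatic carbon and a saturated chain carbon. Among the compounds with values here, this is the same kind of change as the one from compound 2 to compound 1, but not the same: here the carbon that receives the methyl is bound to an aromatic carbon and a saturated chain carbon, whereas in the earlier case it was bound only to an aromatic carbon, so the change reads as ethyl to isopropyl rather than methyl to ethyl.

In this assay a smaller downward step is expected from compound 3 to compound 4, a 1.5-fold lower number from compound 3 to compound 4 (0.16 log units; within the scatter), because a 2.3-fold lower number from compound 2 to compound 1 (0.37 log units; beyond the scatter) shows that adding a methyl at this kind of place lowered the number on a related core, while the different core and surroundings warrant caution. Compound 4 is therefore estimated at 55 nM, most likely between 20 nM and 160 nM.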

Compound 4, half-maximal effective concentration: 14 nM
Compound 4: the middle estimate sits 3.9-fold (0.59 log units) above what was measured; measured number outside the range, below it.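

In this assay, the methyl that turns ethyl into isopropyl gives a 5.7-fold lower number from compound 3 to compound 4 (0.76 log units; beyond the scatter). This step runs in the same direction as the earlier methyl-to-ethyl step on the other core, and the two sizes cannot be told apart: the same change on two cores in this assay, a 2.3-fold lower number (0.37 log units; beyond the scatter) from compound 2 to compound 1 and a 5.7-fold lower number (0.76 log units; beyond the scatter) from compound 3 to compound 4, 2.4-fold (0.39 log units) apart, within the scatter of two such steps. Adding one methyl at this kind of chain carbon therefore lowered the number on both cores, but these two examples do not show that the step is larger on the core of compound 3, that the two different chain changes are equivalent, or that the trend would hold on any further core.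

The compounds shown leave open whether the number in this assay would keep falling with a longer chain such as propyl or butyl, or would follow another course with a ring such as cyclopropyl or with a hydroxyl or an amine at this place. They also leave open what isopropyl would do on the core of compound 1 and what a methyl in place of the ethyl would do on the core of compound 3, two changes that would allow a direct comparison of each chain on both cores.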